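The compounds below may be only part of what the source reports. "The series", "measured", "known", "first", "only" and "open" are said of these compounds alone.

Compounds 1 and 2 share a core in which two aromatic rings are joined through an unsaturated ketone. Compound 1 `COc1cc(-c2cc(/C=C/C(=O)c3ccc(Cl)c(Cl)c3)[nH]n2)cc(OC)c1OC` carries chlorine on the ring of the ketone. In a functional assay on HCT-116 cells (Homo sapiens) for inhibition, read by sulforhodamine B assay, with a stated time of 48 h (a lower number here means that less compound is tolerated, a higher number that more compound is tolerated), compound 1 reaches only a limit, > 100000 nM, which is a limit of the assay and not a number, as the limit of > 100000 nM in this assay, at which 1 of the 2 values shown sits, records. Compound 2 `COc1ccc(-c2cc(/C=C/C(=O)c3cc(OC)c(OC)c(OC)c3)[nH]n2)cc1OC` carries methoxy groups on that ring instead, and in this assay compound 2 gives 5180 nM, the only actual number shown. Compound 3 `COc1cc(C(=O)/C=C/c2cc(-c3cc(OC)c(OC)c(OC)c3)n[nH]2)cc(OC)c1OC` differs from compound 2 by methoxy in place of hydrogen on an aromatic carbon. Among the compounds with values here, no measured step of this kind exists here, so the change is expected to stay within the usual scatter, as a 1.3-fold lower number from compound 2 to compound 3 (0.11 log units; within the scatter). Compound 3 is therefore estimated at 4000 nM, between 1500 nM and 12000 nM.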

Compound 3, concentration lethal to 50% of the cells: 5120 nM
Compound 3: middle estimate off by 1.3-fold (0.11 log units), on the low side; the range from low to high includes it.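

Methoxy in place of hydrogen on this aromatic carbon, ortho to a methoxy group, gives a step within the scatter in this assay (a 1.0-fold lower number from compound 2 to compound 3 (0.01 log units; within the scatter)). Within the data shown here, this is the first measured step at this position, and here the hydrogen and the methoxy group cannot be told apart by this read-out. Nothing available explains this result.

From the compounds shown here alone, it remains open whether an amine or a carboxylic acid at this position would give a step beyond the scatter. The same question stands for a longer chain, such as ethoxy.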